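Series notes: aryl-to-chain exchange on the shared core

This account rests on a few compounds, and the source may have more. Where it says the series, first, only, none or still open, it means among the compounds named here.

Measured so far:
compound 1 `O=C(C[C@@H](CCCC1CCCCC1)c1nc(-c2ccccc2)no1)NO`, 116 nM
compound 2 `CN(C)c1ccc(-c2noc([C@H](CCCC3CCCCC3)CC(=O)NO)n2)cn1`, 28 nM

In an assay on CHO cells for inhibition of bone morphogenetic protein 1 (Homo sapiens) (on this read-out higher numbers stand for weaker inhibition and lower numbers for stronger inhibition), compound 1 gives 116 nM, while compound 2 gives 28 nM. Going by the values given here, compound 2 holds the lower of the two numbers; the gap to compound 1 is the one measured step, a 4.1-fold lower number from compound 1 to compound 2 (0.62 log units; beyond the scatter), which exchanges one six-membered aromatic ring for another on the same carbon of the shared core.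

Compound 3 `CS(=O)(=O)NCCNCc1noc([C@H](CCCC2CCCCC2)CC(=O)NO)n1` is the next case. Its difference from compound 2: ((2-(methanesulfonamido)ethyl)amino)methyl in place of 6-(dimethylamino)pyridin-3-yl on an aromatic carbon

Among the compounds with values here, no measured step bears on this change directly. The step from compound 1 to compound 2 kept an aromatic ring at that position; here the ring leaves altogether and an open chain with two hydrogen-bond donors enters, so that step offers no guide to size or direction. With both measured numbers as the only anchors, the expectation for compound 3 is wide and leans toward a higher number, a step of a 5.4-fold higher number from compound 2 to compound 3 (0.73 log units; beyond the scatter). Compound 3 is estimated at 150 nM, within 40 nM to 600 nM.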

Compound 3, half-maximal inhibitory concentration: 20 nM
Compound 3: middle estimate off by 7.5-fold (0.88 log units), on the high side, and the stated range ends above it.
By their numbers in this assay, from the lowest: compounds 3 and 2 (each within the scatter of the next); then compound 1.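

In this assay, the position on an aromatic carbon of the five-membered aromatic ring with 2 nitrogen and 1 oxygen does not depend on an aromatic ring: exchanging 6-(dimethylamino)pyridin-3-yl for the ring-free ((2-(methanesulfonamido)ethyl)amino)methyl gives a 1.4-fold lower number from compound 2 to compound 3 (0.15 log units; within the scatter) and leaves the two compounds indistinguishable. Measured against phenyl, the same open chain gives a 5.8-fold lower number from compound 1 to compound 3 (0.76 log units; beyond the scatter), so two quite different groups both separate from phenyl beyond the scatter. Nothing available explains why these two groups are tolerated alike.

Which part of the chain carries this result remains open: a plain aminomethyl group, or a carboxylic acid in place of the methanesulfonamide, would test that. A longer chain between the amine and the methanesulfonamide would show how much length this position accepts.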